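Ureas at the melanin-concentrating hormone receptor: aryl swap

A few compounds are considered here, and "the series" means these few. Any claim that something is new, unique, unknown or untested is made for them only; others in the source may bear on it.

compound 1 `CCOc1ccc(-c2cc3ncn([C@H]4CCN(C(=O)N(C)[C@H]5CCN(C)C5)C4)c(=O)c3s2)c(Cl)c1`: 26 nM
compound 2 `COc1ccc(-c2cc3ncn([C@H]4CCN(C(=O)N(C)[C@H]5CCN(C6CCOCC6)C5)C4)c(=O)c3s2)c(C)c1`: 28 nM

In an assay on isolated protein for binding affinity to melanin-concentrating hormone receptor 1 (Homo sapiens) (a lower number here means a stronger inhibitor, a higher number a weaker inhibitor), compound 1 gives 26 nM and compound 2 gives 28 nM; compound 2 holds the higher of the two numbers, but its gap to compound 1 lies within the scatter. Compound 3 `CCOc1ccc(-c2cc3ncn([C@H]4CCN(C(=O)N(C)[C@H]5CCN(C6CCOCC6)C5)C4)c(=O)c3s2)c(Cl)c1` carries 2-chloro-4-ethoxyphenyl in place of 4-methoxy-2-methylphenyl on an aromatic carbon. Going by the values given here, no measured pair isolates this exchange; compound 1 already bears the same aryl group and gives 26 nM, so little movement is anticipated. The step of a 1.2-fold lower number from compound 2 to compound 3 (0.07 log units; within the scatter) is expected to stay within the scatter. Compound 3 is estimated at 24 nM, with a range from 10 nM to 60 nM.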

Compound 3, inhibition constant: 14 nM
Estimate against measurement, compound 3: 1.7-fold (0.23 log units) above; the range from low to high includes it.
By their numbers in this assay, from the lowest: compounds 3, 1 and 2 (each within the scatter of the next).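

At the aromatic carbon next to the ring sulfur, 2-chloro-4-ethoxyphenyl in place of 4-methoxy-2-methylphenyl gives a 2.0-fold lower number from compound 2 to compound 3 (0.30 log units; within the scatter) in this assay, so this exchange is tolerated with oxan-4-yl held constant. On the amine nitrogen in a ring, oxan-4-yl in place of methyl gives a 1.9-fold lower number from compound 1 to compound 3 (0.27 log units; within the scatter), so both groups are tolerated there with the aryl group held constant. No measurement at hand bears on either step.

The aryl exchange alters both substituents at once, leaving the contributions of chloro and ethoxy unseparated. As far as these compounds go, how an acetyl group on that ring nitrogen, or a pyridyl group on the aromatic carbon, would read remains open.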